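The source may report more compounds than this note shows. Statements on the series, on what has been measured and on what is new or still open speak of the compounds shown alone.

The measured compounds are these. Compound 1 `CCCCCCOc1ccc(-n2cnnc2C)cc1` gives 22.8 mg/kg in a functional assay on the whole organism (strain C57B/6) with Mus musculus as the target, in the maximal electroshock model; a lower number here means that less compound is needed, a higher number that more compound is needed for the effect. Compound 2 `CCCCCCOc1ccc(-n2cnnc2CC)cc1` gives 13.2 mg/kg. Compound 3 `CCCCCCOc1ccc(-n2cnnc2CCCCCC)cc1` gives > 40 mg/kg. For compound 3 this is not a number but a limit, (the limit of > 40 mg/kg in this assay, at which 1 of the 3 values shown sits).

Compound 2 differs from compound 1 by methyl in place of hydrogen on a saturated chain carbon bound to an aromatic carbon, and the step is a 1.7-fold lower number from compound 1 to compound 2 (0.24 log units; within the scatter). Compound 3 differs from compound 1 by pentyl in place of hydrogen on a saturated chain carbon bound to an aromatic carbon; the step is an at least 3.0-fold higher number from compound 2 to compound 3 (0.48 log units; beyond the scatter). Compound 4 `CCCCCCCc1nncn1-c1ccc(OCCCCCC)cc1` awaits measurement in this assay and differs from compound 3 by methyl in place of hydrogen on a saturated chain carbon, six bonds along the chain from an aromatic carbon. This is the same kind of change as that from compound 1 to compound 2, yet the place is not the same: there the carbon is bound to an aromatic carbon, here it lies six bonds along the chain from an aromatic carbon. The expected step for compound 4 is a step that the limit leaves unreadable from compound 3 to compound 4, resting on the lengthening already seen as an at least 3.0-fold higher number from compound 2 to compound 3 (0.48 log units; beyond the scatter). Compound 4 is therefore expected near 60 mg/kg, estimated between 30 mg/kg and 150 mg/kg.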

Compound 4, dose for half-maximal effect: > 40 mg/kg
Compound 4: a limit, no number (the forecaster's own chance of this, stated with the estimate: 70%); the middle value does not contradict the limit.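

In this assay compound 4 gives > 40 mg/kg as a limit and not a number. The readable steps are an at least 3.0-fold higher number from compound 2 to compound 4 (0.48 log units; beyond the scatter) and an at least 1.7-fold higher number from compound 1 to compound 4 (0.24 log units; that floor lies within the scatter), while the step between the two limits cannot be read. Set side by side, the pentyl change gives only floors, so it shows no reversal on either core but does not show whether its size carries over: the same change on two cores in this assay, an at least 1.7-fold higher number (0.24 log units; that floor lies within the scatter) from compound 1 to compound 3 and an at least 3.0-fold higher number (0.48 log units; beyond the scatter) from compound 2 to compound 4; the limit leaves it open whether they differ.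

The compounds shown leave open how propyl and butyl chains would read at this place, and how far past the limit compound 3 and compound 4 lie. Also open, from the compounds shown here alone, is how a chain ending in an amine or a carboxylic acid would read there.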